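The source may report more compounds than this note shows. Statements on the series, on what has been measured and on what is new or still open speak of the compounds shown alone.

Measured in an ADME assay on L1210 cells (Mus musculus) for cytotoxicity, with a stated time of 48 h; on this read-out lower numbers stand for stronger inhibition and higher numbers for weaker inhibition:
- Compound 1 `CC1=CCC[C@](C)(CC/C(C)=C/CC2=C(O)C(=O)C=C(N[C@H](C(=O)O)[C@@H](C)O)C2=O)[C@@H]1C`: > 10 ug/mL
- Compound 2 `CC1=CCC[C@](C)(CC/C(C)=C/CC2=C(O)C(=O)C=C(N[C@@H](C(=O)O)[C@@H](C)O)C2=O)[C@@H]1C`: > 10 ug/mL
- Compound 3 `CC1=CCC[C@](C)(CC/C(C)=C/CC2=C(O)C(=O)C=C(N[C@@H](CO)C(=O)O)C2=O)[C@@H]1C`: > 10 ug/mL

Each of these entries is a limit of this assay and not a number. Compound 3 therefore has no exact position on the scale, and the evidence shows that it has company: the limit of > 10 ug/mL in this assay, at which 3 of the 3 values shown sit.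

Compound 4 `CC1=CCC[C@](C)(CC/C(C)=C/CC2=C(O)C(=O)C=C(N[C@@H](C(=O)O)C(C)C)C2=O)[C@@H]1C` has the same core as compound 3 but carries 1-carboxy-2-methylpropyl in place of 1-carboxy-2-hydroxyethyl on an amine nitrogen.

Two measured steps change this same substituent: a step that the two limits leave unreadable from compound 1 to compound 3 and a step that the two limits leave unreadable from compound 2 to compound 3. A third, a step that the two limits leave unreadable from compound 1 to compound 2, alters only the configuration as drawn. None has a readable size, so they offer no guide to the size or direction of the new step. Compound 3 at > 10 ug/mL only anchors the expectation at the limit.

The expected change is a step that the limit leaves unreadable from compound 3 to compound 4, and this estimate has no firm direction. For compound 4 the estimated value is 12 ug/mL, within an expected range from 4 ug/mL to 30 ug/mL.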

Compound 4, half-maximal inhibitory concentration: 3 ug/mL
Compound 4: the middle estimate sits 4.0-fold (0.60 log units) above what was measured, and the stated range ends above it.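

In this assay compound 4 gives 3 ug/mL, the first exact value shown. A change in this group on the amine nitrogen can therefore move the read-out off the limit. The change to 1-carboxy-2-methylpropyl gives an at least 3.3-fold lower number from compound 3 to compound 4 (0.52 log units; beyond the scatter); the related changes give an at least 3.3-fold lower number from compound 2 to compound 4 (0.52 log units; beyond the scatter) and an at least 3.3-fold lower number from compound 1 to compound 4 (0.52 log units; beyond the scatter). Among these four compounds, the three whose side chains carry a hydroxy group all sit at the limit and the one with an isopropyl group does not, and no compound shown goes against this.

From the compounds shown here alone, the steps among compound 1, compound 2 and compound 3 cannot be read, and the full size of the new steps stays open, because those three compounds rest on a limit: the limit of > 10 ug/mL in this assay, at which 3 of the 4 values shown sit. Whether a longer chain or a phenyl ring in place of the isopropyl group would lower the number further also stays open.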